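The source may report more compounds than this note shows. Statements on the series, on what has been measured and on what is new or still open speak of the compounds shown alone.

In a functional assay on SMMC-7721 cells (Homo sapiens) for cytotoxicity, read by MTT assay, with a stated time of 24 h (a lower number here means a stronger inhibitor, a higher number a weaker inhibitor), compound 1 `O=C1/C(=C/c2cccnc2)CN(S(=O)(=O)c2ccccc2)C/C1=C\c1ccccc1F` gives 19100 nM. Compound 2 `O=C1/C(=C/c2ccncc2)CN(S(=O)(=O)c2ccccc2)C/C1=C\c1ccccc1F` differs from compound 1 by pyridin-4-yl in place of pyridin-3-yl on a double-bonded chain carbon bound to a double-bonded ring carbon, and in this assay compound 2 gives 17500 nM. The step that this change made is a 1.1-fold lower number from compound 1 to compound 2 (0.04 log units; within the scatter), so the two values cannot be told apart. Compound 3 `O=C1/C(=C/c2cccnc2)CNC/C1=C\c1ccccc1C(F)(F)F` is built on a different core; the difference between the two cores is not broken down here. In this assay compound 3 gives 5100 nM, the lowest of the three numbers, and its steps to compound 1 and to compound 2 both lie beyond the scatter. Compound 4 `O=C1/C(=C/c2ccncc2)CNC/C1=C\c1ccccc1C(F)(F)F` has not yet been measured in this assay. For the measured compounds named here, it differs from compound 3 by pyridin-4-yl in place of pyridin-3-yl on a double-bonded chain carbon bound to a double-bonded ring carbon, which is the same change as the one between compound 1 and compound 2, made at the same place. Because the earlier step was a 1.1-fold lower number from compound 1 to compound 2 (0.04 log units; within the scatter), a similarly small step is expected on the core of compound 3, namely a 1.1-fold lower number from compound 3 to compound 4 (0.03 log units; within the scatter). Compound 4 is therefore estimated to give 4800 nM in this assay, with a likely range from 2400 nM to 9600 nM.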

Compound 4, half-maximal inhibitory concentration: 4500 nM
For compound 4 the middle estimate is 1.1-fold (0.03 log units) above the measured one, and the stated range covers the measured number.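

In this assay, pyridin-4-yl in place of pyridin-3-yl again gives a step within the scatter, a 1.1-fold lower number from compound 3 to compound 4 (0.05 log units; within the scatter). Set beside the earlier step on the other core, the new step cannot be told apart from it: the same change on two cores in this assay, a 1.1-fold lower number (0.04 log units; within the scatter) from compound 1 to compound 2 and a 1.1-fold lower number (0.05 log units; within the scatter) from compound 3 to compound 4, 1.0-fold (0.02 log units) apart, within the scatter of two such steps. For these two pairs, the change therefore carries from one core to the other as a step too small to read, but this does not show that it would stay as small on any further core, and two steps within the scatter reveal no effect of the change that could be compared in detail.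

The compounds shown leave open whether a pyridine ring bearing an amine or a carboxylic acid at this place would also give so small a step on both cores. They also leave open what the phenylsulfonyl group and the trifluoromethyl group each contribute alone, since the two cores differ in both at once.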